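A few compounds are considered here, and "the series" means these few. Any claim that something is new, unique, unknown or untested is made for them only; others in the source may bear on it.

- compound 1 `CCn1c(C(=O)NCCN(C)C)ccc1C(CC)(CC)c1ccc(OCCC(O)(CC)CC)c(C)c1`: 430 nM
- compound 2 `CCOC(=O)C(CC(=O)OC)NC(=O)c1ccc(C(CC)(CC)c2ccc(OCCC(O)(CC)CC)c(C)c2)n1CC`: 390 nM

Both numbers come from a functional assay on MCF7 cells (Homo sapiens) for antiproliferative activity, read by MTT assay, with a stated time of 48 h; on this read-out higher numbers stand for weaker inhibition and lower numbers for stronger inhibition. Compound 2 gives 390 nM and compound 1 gives 430 nM, so the two sit within the usual scatter of each other and cannot be ranked. Among the measured compounds shown here, compound 2 therefore stands level with the only other measured compound.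

The next compound, compound 3 `CCn1c(C(=O)NC(C)CO)ccc1C(CC)(CC)c1ccc(OCCC(O)(CC)CC)c(C)c1`, keeps the shared core and changes only the group on the amide-type nitrogen: a group of 4 heavy atoms (3 carbon, 1 oxygen; no ring) in place of a group of 11 heavy atoms (7 carbon, 4 oxygen; no ring), on an amide-type nitrogen.

For the measured compounds named here, one measured step bears on this change, since it also swapped the group on that nitrogen: a 1.1-fold lower number from compound 1 to compound 2 (0.04 log units; within the scatter). That swap left the number inside the scatter, so this position has so far shown no measurable effect in this assay. This is thin evidence, as it rests on a single step and the group in compound 3 has not been tested. Even so, no shift beyond the scatter is expected, in either direction. The expected change is a 1.0-fold higher number from compound 2 to compound 3 (0.01 log units; within the scatter). For compound 3 the estimated value is 400 nM, with an expected range from 150 nM to 1100 nM.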

Compound 3, half-maximal inhibitory concentration: 12600 nM
The estimate for compound 3 lay 32-fold (1.50 log units) below the measured number; measured number outside the range, above it.
By their numbers in this assay, from the lowest: compounds 2 and 1 (each within the scatter of the next); then compound 3.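

In this assay, the group on the amide-type nitrogen turns out to matter a great deal: putting 1-(hydroxymethyl)ethyl there weakens inhibition sharply, whether it is set against the ester-bearing group of compound 2 (a 32-fold higher number from compound 2 to compound 3 (1.51 log units; beyond the scatter)) or against the 2-(dimethylamino)ethyl of compound 1 (a 29-fold higher number from compound 1 to compound 3 (1.47 log units; beyond the scatter)). The earlier flat step between compound 1 and compound 2 therefore did not mean that this position accepts anything; it meant only that those two quite different groups happen to give values within the scatter of each other. No measurement at hand accounts for the loss seen with compound 3.

The compounds shown leave open which part of the 1-(hydroxymethyl)ethyl group goes with the higher number, the hydroxyl or the branching methyl, and whether the shared feature of the two better groups lies in their length or in something else. A plain ethyl group, a straight 2-hydroxyethyl chain, a longer chain ending in an amine, or a carboxylic acid on this nitrogen would help to tell these apart.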